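Ethoxy for bromo on a hydrazone aryl ring

The compounds below may be only part of what the source reports. "The series", "measured", "known", "first", "only" and "open" are said of these compounds alone.

Compound 2, `CC1CC/C(=N\Nc2ccc(Br)cc2)c2ncc(C(=O)O)c(=O)n21`, is one of three close relatives tested in a functional assay on the whole organism for inhibition, with Rattus norvegicus as the target; a lower number here means that less compound is needed, a higher number that more compound is needed for the effect. In this assay compound 2 reaches only a limit of the assay, > 1000 umol/kg, and not a number. Compound 1, `CC1CC/C(=N\Nc2cccc(Cl)c2)c2ncc(C(=O)O)c(=O)n21`, likewise gives only a limit in this assay, > 100 umol/kg. Compound 3, `CC1CC/C(=N\Nc2ccccc2O)c2ncc(C(=O)O)c(=O)n21`, also stops at a limit in this assay, > 100 umol/kg. So every value shown for this set is a limit: the limit of > 100 umol/kg in this assay, at which 2 of the 3 values shown sit, and (the limit of > 1000 umol/kg in this assay, at which 1 of the 3 values shown sits). The steps among them, a step that the two limits leave unreadable from compound 1 to compound 2, a step that the two limits leave unreadable from compound 1 to compound 3 and a step that the two limits leave unreadable from compound 2 to compound 3, therefore cannot be sized, and compound 2 stands at the highest of the limits recorded.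

Compound 4, `CCOc1ccc(N/N=C2\CCC(C)n3c2ncc(C(=O)O)c3=O)cc1`, differs from compound 2 as follows: ethoxy in place of bromo on an aromatic carbon. Ethoxy enters on an aromatic carbon of a six-membered aromatic ring of carbon only, para to a large group, where bromo leaves.

Going by the values given here, no measured step bears on this change with a readable size, since all three steps are unreadable. The account therefore expects no step beyond the scatter, and the step from compound 2 to compound 4 is estimated as a number no higher from compound 2 to compound 4 (the limit leaves the size open). Compound 4 is expected to give about 1000 umol/kg in this assay, within a range from 100 umol/kg to 3000 umol/kg, most likely again reported as a limit.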

Compound 4, dose for 50% inhibition: > 100 umol/kg
Compound 4 gave a limit, no number (the forecaster's own chance of this, stated with the estimate: 85%); the middle value lies beyond the limit too.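

In this assay compound 4 gives > 100 umol/kg, which is a limit of the assay and not a number. Compound 2 also gives only a limit, so the step to compound 4 cannot be read. The compounds shown leave open how ethoxy and bromo compare on the aromatic ring, and what dose any of the four compounds needs for the effect.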